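Swapping Dimethylamino for Diethylamino on the Shorter Chain

This account rests on a few compounds, and the source may have more. Where it says the series, first, only, none or still open, it means among the compounds named here.

Compound 1 `CN(C)CCCn1c(N)c(-c2nc3ccccc3n2C)c2nc(C#N)c(C#N)nc21` gives 11700 nM in a functional assay on A549 cells (Homo sapiens) for antiproliferative activity, read by MTT assay, with a stated time of 48 h; a lower number here means a stronger inhibitor, a higher number a weaker inhibitor.
Compound 2 `CCN(CC)CCCn1c(N)c(-c2nc3ccccc3n2C)c2nc(C#N)c(C#N)nc21` gives 10700 nM in this assay.
Compound 3 `CN(C)CCn1c(N)c(-c2nc3cc(Cl)ccc3[nH]2)c2nc(C#N)c(C#N)nc21` gives only a limit of the assay, > 50000 nM, in this assay.

Compound 1 and compound 2 share a core and differ by one group: diethylamino in place of dimethylamino on a saturated chain carbon, three bonds along the chain from an aromatic nitrogen. The measured step is a 1.1-fold lower number from compound 1 to compound 2 (0.04 log units; within the scatter), so the two values cannot be told apart.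

Compound 3 carries a different core, and the difference between the two cores is not broken down here. What is known of compound 3 is that it sits at the limit of > 50000 nM in this assay, at which 1 of the 3 values shown sits.

Compound 4 `CCN(CC)CCn1c(N)c(-c2nc3cc(Cl)ccc3[nH]2)c2nc(C#N)c(C#N)nc21` has not been measured. It differs from compound 3 in the same way: diethylamino in place of dimethylamino on a saturated chain carbon, two bonds along the chain from an aromatic nitrogen. The place is not identical, since in compound 1 and compound 2 the amine sits three bonds along the chain from the aromatic nitrogen and in compound 3 and compound 4 two bonds along, so this is the same kind of change rather than the same change.

Because the measured step of a 1.1-fold lower number from compound 1 to compound 2 (0.04 log units; within the scatter) lay within the scatter, the expected step from compound 3 to compound 4 is a step that the limit leaves unreadable from compound 3 to compound 4, essentially no change. Since compound 3 reached only a limit, compound 4 is expected to give 70000 nM in this assay, between 30000 nM and 200000 nM, and most likely to be reported again as a limit.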

Compound 4, half-maximal inhibitory concentration: > 50000 nM
Compound 4: only a limit was reported; the forecaster's own chance of this, stated with the estimate: 75%; the middle value is on the limit's open side.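

Compound 3 and compound 4 each gave only a limit of the assay in this assay, so no step between them can be read: the limit of > 50000 nM in this assay, at which 2 of the 4 values shown sit.

The compounds shown leave open what diethylamino in place of dimethylamino does on the chain of compound 3 and compound 4, and which of their differences from compound 1 and compound 2 separates these two pairs.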